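Trimming a Methoxy Group: From Compound 3 to Compound 4

A few compounds are considered here, and "the series" means these few. Any claim that something is new, unique, unknown or untested is made for them only; others in the source may bear on it.

Three compounds have so far been measured in an assay on isolated protein for inhibition of Aromatase (Homo sapiens), tested at 1 uM; a lower number here means less inhibition, a higher number more inhibition at the concentration tested (going by the name of the read-out):

Compound 1, `CC(C)OCC1n2cncc2CN([C@@H](C)c2ccc(Cl)cc2)S1(=O)=O`, gives 23%.
Compound 2, `C[C@@H](c1ccc(Cl)cc1)N1Cc2cncn2C(C[C@H](O)c2ccccc2)S1(=O)=O`, gives 6%.
Compound 3, `COC(C)(C)CC1n2cncc2CN([C@@H](C)c2ccc(Cl)cc2)S1(=O)=O`, gives 17%.

Compound 3 stands second highest of the three numbers. Its nearest neighbour is compound 1: the step is a number 6 percentage points lower from compound 1 to compound 3 (within the scatter), which lies within the scatter, so the two cannot be ordered. Against compound 2 the step is a number 11 percentage points higher from compound 2 to compound 3 (beyond the scatter), a modest difference beyond the scatter.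

Compound 4, `CC(C)CC1n2cncc2CN([C@@H](C)c2ccc(Cl)cc2)S1(=O)=O`, is the next compound in line. It differs from compound 3 as follows: hydrogen in place of methoxy on a saturated chain carbon bound to three saturated chain carbons.

Both measured steps touch the same chain on the saturated ring carbon. The exchange of isopropoxy for 1-methoxy-1-methylethyl moved the read-out only within the scatter, while the exchange of hydroxy(phenyl)methyl for 1-methoxy-1-methylethyl moved it modestly. The present change removes only a methoxy from that chain, a smaller alteration than either measured step, so a step within the scatter is expected, leaning if anything slightly downward.

On that basis compound 4 is estimated at 14%, with a range from 4% to 28%, an expected step of a number 3 percentage points lower from compound 3 to compound 4 (within the scatter).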

Compound 4, a percentage reported as inhibition, at one concentration (the size of the read-out at that concentration, not a potency): 56%
Compound 4: middle estimate off by 42 percentage points, on the low side; measured number above the stated range.
By their numbers in this assay, from the lowest: compound 2; then compounds 3 and 1 (each within the scatter of the next); then compound 4.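

In this assay, among these compounds, the loss of methoxy alone, 1-methoxy-1-methylethyl giving way to isopropyl, brings a number 39 percentage points higher from compound 3 to compound 4 (beyond the scatter) and shows that this chain responds far more strongly to a small change than the earlier compounds suggested, since a number 6 percentage points lower from compound 1 to compound 3 (within the scatter) had stayed inside the usual variation. The other two comparisons point the same way, with a number 33 percentage points higher from compound 1 to compound 4 (beyond the scatter) for isopropyl in place of isopropoxy and a number 50 percentage points higher from compound 2 to compound 4 (beyond the scatter) for isopropyl in place of hydroxy(phenyl)methyl, which places compound 4 clearly highest of the four and makes it the only one whose chain ends without an oxygen atom, a pattern that holds for these four compounds alone. No measurement offered here bears on why the number rises so sharply.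

As far as these compounds go, it remains open whether other oxygen-free chains at this place, such as a longer chain like n-pentyl or a cyclohexylmethyl group, would match compound 4, or whether an amine in place of the methoxy would behave like the ethers. From the compounds shown here alone, since this assay reports inhibition at a single concentration, the potency of compound 4 also remains unknown.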